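This account rests on a few compounds, and the source may have more. Where it says the series, first, only, none or still open, it means among the compounds named here.

Three compounds share one core, a sulfonamide bearing two trifluoromethyl groups and linked through a short chain to a benzylic amine. Compound 1 `O=S(=O)(NCCCNCc1ccc(Cl)c(Cl)c1)c1cc(C(F)(F)F)cc(C(F)(F)F)c1` carries a 3,4-dichlorophenyl group; in a functional assay on MCF7 cells (Homo sapiens) for inhibition, read by MTT assay, with a stated time of 72 h (a lower number here means a stronger inhibitor of growth, a higher number a weaker inhibitor of growth), compound 1 gives 2400 nM. Compound 2 `O=S(=O)(NCCCNCc1ccc(C(F)(F)F)cc1)c1cc(C(F)(F)F)cc(C(F)(F)F)c1` carries a 4-(trifluoromethyl)phenyl group instead, and in this assay compound 2 gives 1400 nM. Compound 3 `O=S(=O)(NCCCNCc1ccccc1)c1cc(C(F)(F)F)cc(C(F)(F)F)c1` carries a plain phenyl group, and in this assay compound 3 gives 3000 nM, the highest of the three numbers. The step from compound 1 to compound 3 is a 1.3-fold higher number from compound 1 to compound 3 (0.10 log units; within the scatter), while the step from compound 2 to compound 3 is a 2.1-fold higher number from compound 2 to compound 3 (0.33 log units; beyond the scatter).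

Compound 4 `COc1ccc(CNCCCNS(=O)(=O)c2cc(C(F)(F)F)cc(C(F)(F)F)c2)cc1` follows from compound 3 by one change: methoxy in place of hydrogen on an aromatic carbon, that is, a methoxy group in place of hydrogen on an aromatic carbon, para to a large group, turning benzylamino into (4-methoxybenzyl)amino. Within the data shown here, no measured step introduces a methoxy group, so the closest guides are the substitutions on that same ring: one within the scatter, one modest and beyond it. A substituted ring has so far given a number no higher than the plain ring, so compound 4 is expected to show a step of a 1.2-fold lower number from compound 3 to compound 4 (0.08 log units; within the scatter), small and most likely within the scatter. The estimate for compound 4 in this assay is 2500 nM, with a range from 1200 nM to 5000 nM.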

Compound 4, concentration for 50% growth inhibition: 2500 nM
For compound 4 middle estimate and measured number coincide at the digits printed; the measured number falls inside the stated range.
By their numbers in this assay, from the lowest: compounds 2, 1, 4 and 3 (each within the scatter of the next, the first and the last beyond it).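

In this assay, among these compounds, methoxy is the first group on this ring to carry an oxygen, and placing it para to a large group on the plain ring changes the number only within the scatter (a 1.2-fold lower number from compound 3 to compound 4 (0.08 log units; within the scatter)). Compound 4 also stays within the scatter of the two other substituted compounds when methoxy replaces trifluoromethyl (a 1.8-fold higher number from compound 2 to compound 4 (0.25 log units; within the scatter)) and when 4-methoxyphenyl replaces 3,4-dichlorophenyl (a 1.0-fold higher number from compound 1 to compound 4 (0.02 log units; within the scatter)), so it cannot be assigned to either side of the one modest gap, the step that separates compound 2 from compound 3. No measurement here offers an explanation for these small steps.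

Going by these compounds, it remains open whether a hydroxyl, a nitrile or a dimethylamino group at this same place on the ring would produce a step beyond the scatter, or whether the numbers would stay in this narrow band. The shown compounds also leave untested how a longer chain linking the sulfonamide to the amine, or a replacement for the two trifluoromethyl groups on the sulfonyl side, would affect growth inhibition.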